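The compounds below may be only part of what the source reports. "The series", "measured", "known", "first", "only" and "open" are said of these compounds alone.

Measured so far in an ADME assay on BHK cells (Mesocricetus auratus) for cytotoxicity, read by MTT assay, with a stated time of 96 h; on this read-out lower numbers stand for higher toxicity in this test and higher numbers for lower toxicity in this test:

compound 1 `Nc1ccc(-c2nc3cc(Cl)c(Cl)cc3[nH]2)cc1` gives 30000 nM
compound 2 `O=[N+]([O-])c1ccc(-c2nc3cc(Cl)c(Cl)cc3[nH]2)cc1` reaches only a limit of the assay, > 100000 nM
compound 3 `COc1ccc(-c2nc3cc(C(F)(F)F)ccc3[nH]2)c([N+](=O)[O-])c1` gives 100000 nM

Compound 2 stands at a limit and not at a number, so the step of an at least 3.3-fold lower number from compound 2 to compound 1 (0.52 log units; beyond the scatter) is known only as a lower bound because the limit of > 100000 nM in this assay, at which 1 of the 3 values shown sits, is what is recorded for compound 2. The change behind that step is amino in place of nitro on an aromatic carbon. Compound 3 holds the highest of the two numbers in this assay; its nearest neighbour is compound 1, a step beyond the scatter. The difference between the core of compound 3 and the core of compound 2 is not broken down here.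

Compound 4 `COc1ccc(-c2nc3cc(C(F)(F)F)ccc3[nH]2)c(N)c1` has not yet been measured. It differs from compound 3 by amino in place of nitro on an aromatic carbon. This is the same kind of change as that from compound 2 to compound 1, but the place is not the same: in compound 1 the amino sits para to a large group, whereas in compound 4 it sits ortho to a large group and meta to a methoxy group. In this assay a step of a 2.9-fold lower number from compound 3 to compound 4 (0.46 log units; beyond the scatter) is expected, set beside an at least 3.3-fold lower number from compound 2 to compound 1 (0.52 log units; beyond the scatter), resting on compound 3 at 100000 nM and on the earlier step. Compound 4 is therefore expected near 35000 nM, with the estimate spanning 10000 nM to 100000 nM.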

Compound 4, half-maximal cytotoxic concentration: >= 100000 nM
Compound 4: a limit, no number (the forecaster's own chance of this, stated with the estimate: 15%); middle value at least 2.8-fold (0.45 log units) from the limit.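

Amino in place of nitro on an aromatic carbon does not carry over as one fixed shift from the core of compound 2 to the core of compound 3 in this assay: the same change on two cores in this assay, an at least 3.3-fold lower number (0.52 log units; beyond the scatter) from compound 2 to compound 1 and a number no lower (the limit leaves the size open) from compound 3 to compound 4, at least 3.3-fold (0.52 log units) apart, beyond the scatter of two such steps

Compound 4 stands at a limit of the assay, >= 100000 nM, and not at a number. Among these compounds, the new step reads a number no lower from compound 3 to compound 4 (the limit leaves the size open), so the fall in the number seen on the first pair does not appear on the second, but this rests on only two pairs, and both carry a limit; it does not show whether the different core or the different place of the amino, here ortho to a large group and meta to a methoxy group, lies behind the gap, since the two vary together.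

The compounds shown leave open where compound 2 and compound 4 would fall on a scale that reached past their limits, and so how large either step truly is. They also leave open whether a hydroxyl, an acetamide or a dimethylamino group in the same place would follow the amino on either core.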